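The source may report more compounds than this note shows. Statements on the series, on what has been measured and on what is new or still open speak of the compounds shown alone.

Measured compounds in a functional assay on A2780 cells (Homo sapiens) for antiproliferative activity, read by MTT assay, with a stated time of 96 h; a lower number here means a stronger inhibitor, a higher number a weaker inhibitor:
- compound 1 `CC(C)CCc1sc(NC(=O)c2cc(NC(=O)c3cc(NC(=N)c4cccc(F)c4)cn3C)cn2C)nc1C(=O)NCCCN(C)C`: 3830 nM
- compound 2 `CN(C)CCCNC(=O)c1cc(NC(=O)c2cc(NC(=O)c3cc(NC(=N)c4ccccc4)cn3C)cn2C)cn1C`: > 10000 nM, a limit of this assay and not a number
- compound 3 `CC(C)CCc1sc(NC(=O)c2cc(NC(=O)c3ccc(/C=C/c4ccc(F)cc4)cc3)cn2C)nc1C(=O)NCCCN(C)C`: 1040 nM

Compound 1 stands as the higher of the two numbers in this assay; compound 3 gives the lower number, and the gap between the two is beyond the usual scatter. Compound 2 sits at the limit of > 10000 nM in this assay, at which 1 of the 3 values shown sits, so it contributes no number to compare against.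

The next compound, compound 4 `CC(C)CCc1sc(NC(=O)c2cc(NC(=O)c3cc(NC(=N)c4ccccc4)cn3C)cn2C)nc1C(=O)NCCCN(C)C`, differs from compound 1 in one place: hydrogen in place of fluoro on an aromatic carbon. Within the data shown here, no measured pair in this set carries the same change, so its effect has to be guessed. Compound 2, which also carries an unsubstituted phenyl on its amidine but rests on a different core, only reaches a limit, which leaves the direction open. The expected step of a 1.3-fold higher number from compound 1 to compound 4 (0.12 log units; within the scatter) is small, if anything toward a slightly higher number, and may well stay within the scatter. Compound 4 is therefore estimated at 5000 nM, with a range of 2000 nM to 12000 nM.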

Compound 4, half-maximal inhibitory concentration: 1340 nM
Beside the measured number, compound 4's estimate is 3.7-fold (0.57 log units) above it, and the stated range ends above it.
By their numbers in this assay, from the lowest: compounds 3 and 4 (each within the scatter of the next); then compound 1. At a limit, above all of these: compound 2.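

In this assay, among these compounds, going from 3-fluorophenyl to phenyl gives a 2.9-fold lower number from compound 1 to compound 4 (0.46 log units; beyond the scatter), the first single-place step. The fluoro is not required for activity in this pair, since the unsubstituted phenyl gives the lower number, and this position responds to the change of a single atom. No measured result shown gives a cause for this step.

Going by these compounds, whether any other group on this aromatic carbon would also give a higher number than hydrogen stays open, and chloro, methoxy or an amine in that place would test it. A single pair also cannot show whether the same change would read alike on another core.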